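Solubility notes: amide-side change from carboxycyclobutyl to hydroxypropyl

This account rests on a few compounds, and the source may have more. Where it says the series, first, only, none or still open, it means among the compounds named here.

Compound 1 `CCC(C)(C)NS(=O)(=O)c1ccc(-c2sc(C(=O)N[C@H]3C[C@H](C(=O)O)C3)nc2CC2CCCCC2)c(Cl)c1C` — in a physicochemical assay for solubility, read by HPLC, in phosphate buffer, measured as thermodynamic solubility, with a stated time of 5 days, at pH 7, tested at 10 mM (on this read-out higher numbers stand for higher solubility and lower numbers for lower solubility), compound 1 gives < 1000 nM, which is a limit of the assay rather than a number.
Compound 2 `CC(C)NS(=O)(=O)c1ccc(-c2sc(C(=O)N[C@H]3C[C@H](C(=O)O)C3)nc2CC2CCCCC2)c(C(F)F)c1Cl` — compound 2 gives 11000 nM.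
Compound 3 `CC(C)(C)NS(=O)(=O)c1ncc(-c2sc(C(=O)N[C@H]3C[C@H](C(=O)O)C3)nc2CC2CCCCC2)c2ccccc12` — compound 3 gives 13000 nM.

Compound 3 and compound 2 sit within the scatter of each other, so no order between them is read. Compound 1 sits at a limit (the limit of < 1000 nM in this assay, at which 1 of the 3 values shown sits), and that is all that value shows.

Compound 4 `CC(C)(O)CNC(=O)c1nc(CC2CCCCC2)c(-c2cnc(S(=O)(=O)NC(C)(C)C)c3ccccc23)s1` differs from compound 3 in one place: 2-hydroxy-2-methylpropyl in place of 3-carboxycyclobutyl on an amide-type nitrogen. For the measured compounds named here, no measured pair among the three compounds shows a change of this kind, so the step is judged from the structural change alone.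

The expectation for compound 4 in this assay is a drop beyond the scatter, a 4.3-fold lower number from compound 3 to compound 4 (0.64 log units; beyond the scatter). Compound 4 is estimated at 3000 nM, with a range from 600 nM to 15000 nM.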

Compound 4, solubility: < 4000 nM
Compound 4 was reported as a limit (the forecaster's own chance of this, stated with the estimate: 25%); the middle value is on the limit's open side.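

In this assay compound 4 gives < 4000 nM, which is a limit of the assay and not a number. The amide-type nitrogen now has its first one-place step, with 2-hydroxy-2-methylpropyl in place of 3-carboxycyclobutyl: an at least 3.2-fold lower number from compound 3 to compound 4 (0.51 log units; beyond the scatter). The size of this step is fixed on one side only: the limit of < 4000 nM in this assay, at which 1 of the 4 values shown sits.

The compounds shown leave open whether this step follows the loss of the carboxylic acid or the loss of the four-membered ring. An open-chain carboxylic acid or a hydroxycyclobutyl group on the same nitrogen would separate the two.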